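This account rests on a few compounds, and the source may have more. Where it says the series, first, only, none or still open, it means among the compounds named here.

Measured compounds in a functional assay on MCF7 cells (Homo sapiens) for inhibition, read by sulforhodamine B assay, with a stated time of 48 h; a lower number here means a stronger inhibitor of growth, a higher number a weaker inhibitor of growth:
- compound 1 `O=C(Nc1cccc(-n2cc(-c3ccncc3)c(-c3ccc(Cl)c(O)c3)n2)c1)Nc1cccc(C(F)(F)F)c1`: 1340 nM
- compound 2 `COc1cc(-c2nn(-c3cccc(NC(=O)Nc4cccc(C(F)(F)F)c4)c3)cc2-c2ccncc2)ccc1Cl`: 751 nM
- compound 3 `COc1cc(-c2nn(-c3cccc(NC(=O)c4ccc(Cl)c(C(F)(F)F)c4)c3)cc2-c2ccncc2)ccc1Cl`: 2240 nM

Compound 3 gives the highest number of the three. Its nearest neighbour is compound 1, and the gap between them is within the scatter; the step of a 3.0-fold higher number from compound 2 to compound 3 (0.47 log units; beyond the scatter) is the only one beyond the scatter in the set. The other measured step, a 1.8-fold lower number from compound 1 to compound 2 (0.25 log units; within the scatter), is within the scatter and concerns the oxygen substituent on the shared core, not the carbonyl.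

Compound 4 `COc1cc(-c2nn(-c3cccc(NC(=O)c4ccccc4)c3)cc2-c2ccncc2)ccc1Cl` is not yet measured. It differs from compound 3 in one place: phenyl in place of 4-chloro-3-(trifluoromethyl)phenyl on a carbonyl carbon. Among the compounds with values here, of the measured steps, only the step from compound 2 to compound 3 touches the carbonyl carbon, and it swaps an amino group for an aryl group rather than changing the substituents on an aryl group already present. Within the data shown here, no measured pair shows the effect of removing a chlorine and a trifluoromethyl from that ring, so the data give no direct guide.

Without a bearing step, the working expectation for compound 4 in this assay is no step beyond the scatter, a 1.1-fold higher number from compound 3 to compound 4 (0.05 log units; within the scatter), with a wide range. Compound 4 is therefore estimated at 2500 nM, between 900 nM and 7000 nM.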

Compound 4, concentration for 50% growth inhibition: 335 nM
Estimate against measurement, compound 4: 7.5-fold (0.87 log units) above; measured number below the stated range.
By their numbers in this assay, from the lowest: compound 4; then compounds 2, 1 and 3 (each within the scatter of the next, the first and the last beyond it).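

In this assay, within the data shown here, the carbonyl carbon bonded to the amide-type nitrogen carries plain phenyl at a lower number than 4-chloro-3-(trifluoromethyl)phenyl (a 6.7-fold lower number from compound 3 to compound 4 (0.83 log units; beyond the scatter)), the first direct reading of what the substituents on this ring are worth, and here the group with fewer heavy atoms is favoured over the larger one. The higher number of compound 3 relative to compound 2 therefore cannot be read as a penalty for an aryl group on the carbonyl as such, since the unsubstituted aryl group falls on the other side of the (3-(trifluoromethyl)phenyl)amino group (a 2.2-fold lower number from compound 2 to compound 4 (0.35 log units; beyond the scatter)). No measurement is available that would explain either step.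

Chlorine and trifluoromethyl leave together in this change, so their separate contributions remain unresolved, as does whether either alone would raise the number. Also open, from the compounds shown here alone, is how this position responds to a nitrile, an amine or a carboxylic acid on the phenyl ring, or to a longer chain between the carbonyl and the ring.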